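The source may report more compounds than this note shows. Statements on the series, on what has been measured and on what is new or still open speak of the compounds shown alone.

Measured compounds:
compound 1 `C=CCc1cc(C(C)=O)c(O)cc1OCCCCCCCC#N`: 88%
compound 2 `CCc1cc(C(C)=O)c(O)cc1OCCCC(C)(C)C#N`: 85%

In an assay on isolated protein for inhibition of leukotriene B4 receptor 1 (Homo sapiens), tested at 10 uM (a lower number here means less inhibition, a higher number more inhibition at the concentration tested (going by the name of the read-out)), compound 1 gives 88%, the higher of the two numbers recorded so far, and compound 2 gives 85%. The two numbers lie within the scatter of each other, so no order between the two compounds can be read from them. Within the data shown here, both measured compounds carry a nitrile at the end of the chain attached to the oxygen on the aromatic ring; no measured pair shows what happens when that nitrile is taken away.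

Compound 3 `C=CCc1cc(C(C)=O)c(O)cc1OCCCCCC` has not yet been measured in this assay. It differs from compound 1 as follows: hydrogen in place of cyanomethyl on a saturated chain carbon, six bonds along the chain from an oxygen on an aromatic ring. Among the measured compounds shown here, nothing among the measured compounds speaks directly to this change, so the expectation rests on the general observation that compound 1 sits high and a chain-end change of this kind is more likely to cost than to gain. Expected is a drop in this assay of a number 18 percentage points lower from compound 1 to compound 3 (beyond the scatter), with wide uncertainty. Compound 3 is estimated at 70%, with a range from 40% to 90%.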

Compound 3, a percentage reported as inhibition, at one concentration (the size of the read-out at that concentration, not a potency): 50%
Compound 3: the middle estimate sits 20 percentage points above what was measured; the range from low to high includes it.
By their numbers in this assay, from the lowest: compound 3; then compounds 2 and 1 (each within the scatter of the next).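

In this assay, among these compounds, hydrogen in place of cyanomethyl on a saturated chain carbon, six bonds along the chain from an oxygen on an aromatic ring, gives a number 38 percentage points lower from compound 1 to compound 3 (beyond the scatter) and is the first single-place step, showing that the chain end bearing the nitrile is not indifferent at this position. The change does not remove inhibition altogether, as compound 3 still gives 50% at the concentration tested, so part of the read-out remains without the cyanomethyl group. No available data bear on the reason for this step.

The step removes the nitrile and shortens the chain together, so the compounds shown do not separate the contribution of the nitrile from that of the chain carbons lost with it. Open, too, is how a plain alkyl chain of the same length as in compound 1, or a carboxylic acid or primary amide at the chain end, would compare with the nitrile on the same core.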